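Clearance notes on the shared core: compound 3 to compound 4

The source may hold more compounds than are shown below. What is called first, only, known or untested is meant among the compounds shown, and "the series" means these compounds.

In an ADME assay on microsomes from liver (Homo sapiens) for metabolic stability, read by LC-MS, using NADPH, with stated times of 5 min and 30 min, tested at 1 uM (a lower number here means slower removal, a higher number faster removal of the compound), compound 1 `O=C(Nc1ccccc1)c1cnc(NCc2c(F)ccc3c2CCO3)n2cnnc12` gives 14 mL.min-1.g-1, compound 2 `O=C(Nc1cnc(NCc2c(F)ccc3c2CCO3)n2cnnc12)c1ccccc1` gives 10 mL.min-1.g-1 and compound 3 `CN(c1ccn(C)n1)c1cnc(NCc2c(F)ccc3c2CCO3)n2cnnc12` gives 11 mL.min-1.g-1. Compound 3 sits within the scatter of both others: the step of a 1.3-fold lower number from compound 1 to compound 3 (0.10 log units; within the scatter) and the step of a 1.1-fold higher number from compound 2 to compound 3 (0.04 log units; within the scatter) are each too small to read as a change, as is the step of a 1.4-fold lower number from compound 1 to compound 2 (0.15 log units; within the scatter) between the two earlier compounds. Across the three measured compounds the group on this aromatic carbon has therefore made no visible difference to this assay.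

Compound 4 `COCCC(=O)Nc1cnc(NCc2c(F)ccc3c2CCO3)n2cnnc12` carries the change (((2-methoxyethyl)carbonyl)amino in place of methyl(1-methyl-1H-pyrazol-3-yl)amino on an aromatic carbon). Within the data shown here, the steps that bear on it are the exchanges of the same position already measured, above all a 1.1-fold higher number from compound 2 to compound 3 (0.04 log units; within the scatter), which swaps an amide-linked group for the pyrazolyl amine, and a 1.3-fold lower number from compound 1 to compound 3 (0.10 log units; within the scatter); both stayed inside the scatter. Among the measured compounds shown here, no measured step covers the ((2-methoxyethyl)carbonyl)amino group itself, so its own contribution is unknown. Given that every exchange at this position so far left this assay unchanged, the step of no change at the digits printed from compound 3 to compound 4 (within the scatter) is expected to stay within the scatter. Compound 4 is accordingly estimated at 11 mL.min-1.g-1, with a range of 5 mL.min-1.g-1 to 25 mL.min-1.g-1.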

Compound 4, intrinsic clearance in microsomes: < 3 mL.min-1.g-1
Compound 4: a limit, no number; the forecaster's own chance of this, stated with the estimate: 5%; middle value at least 3.6-fold (0.56 log units) from the limit.
By their numbers in this assay, from the lowest: compounds 2, 3 and 1 (each within the scatter of the next). At a limit, below all of these: compound 4.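

In this assay compound 4 gives < 3 mL.min-1.g-1, which is a limit of the assay and not a number, and it is the only compound shown that sits there: the limit of < 3 mL.min-1.g-1 in this assay, at which 1 of the 4 values shown sits.

This position is therefore not indifferent to the group it carries, as the three earlier compounds suggested: ((2-methoxyethyl)carbonyl)amino in place of methyl(1-methyl-1H-pyrazol-3-yl)amino gives an at least 3.6-fold lower number from compound 3 to compound 4 (0.56 log units; beyond the scatter), and the exchange for phenylcarbamoyl gives an at least 4.6-fold lower number from compound 1 to compound 4 (0.66 log units; beyond the scatter). The closest comparison is 2-methoxyethyl in place of phenyl on a carbonyl carbon, which gives an at least 3.3-fold lower number from compound 2 to compound 4 (0.52 log units; beyond the scatter); the amide link is present on both sides of that step, so the link alone does not separate compound 4 from the others, and among the compounds shown the step follows the loss of the aromatic ring from the group on the carbonyl.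

From the compounds shown here alone, since the value of compound 4 is a limit, the full size of these steps remains open. Going by these compounds, it also remains open whether the change follows the ether oxygen or the open chain itself, which a plain propyl chain, a longer chain or a chain ending in an amine on the same carbonyl would help to separate.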